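Nitro on the core: a second place to test

A few compounds are considered here, and "the series" means these few. Any claim that something is new, unique, unknown or untested is made for them only; others in the source may bear on it.

Compound 1 `O=C(NO)c1cc2ccccc2s1` gives 28000 nM
Compound 2 `O=C(NO)c1cc2cc([N+](=O)[O-])ccc2s1` gives 34000 nM

In an ADME assay on Huh-7 cells (Homo sapiens) for inhibition, with a stated time of 3 days (a higher number here means that more compound is tolerated, a lower number that less compound is tolerated), compound 1 has one measured neighbour, compound 2, and their two numbers lie within the scatter of each other. Compound 3 `O=C(NO)c1cc2ccc([N+](=O)[O-])cc2s1` is still unmeasured. It differs from compound 1 as follows: nitro in place of hydrogen on an aromatic carbon. That is nitro in place of hydrogen on an aromatic carbon. Among the measured compounds shown here, the one measured step of this kind is a 1.2-fold higher number from compound 1 to compound 2 (0.08 log units; within the scatter), and it is no larger than the scatter. A single step is thin evidence, and the new place on the core has not been tested, so the range stays wide. No step beyond the scatter is expected in this assay, in either direction. The estimated change is a 1.1-fold higher number from compound 1 to compound 3 (0.03 log units; within the scatter). For compound 3 the expected value is 30000 nM, with an estimated range of 13000 nM to 55000 nM.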

Compound 3, half-maximal cytotoxic concentration: 54000 nM
For compound 3 the middle estimate is 1.8-fold (0.26 log units) below the measured one; low and high end bracket the measured number.
By their numbers in this assay, from the lowest: compounds 1, 2 and 3 (each within the scatter of the next).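

In this assay, nitro in place of hydrogen at this second place, an aromatic carbon of the six-membered ring, gives a 1.9-fold higher number from compound 1 to compound 3 (0.29 log units; within the scatter). With compound 2, this means that nitro has now been tried at two places on the shared core, and in each case the number stays within the scatter of compound 1, so these compounds give no sign that either place matters for how much compound the cells tolerate. No measurement here offers an explanation for these numbers.

From the compounds shown here alone, whether a different group at this place, such as an amine or a carboxylic acid, would also stay within the scatter remains open. The same question stands for the other aromatic carbons of the core.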